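Swapping a Fluorinated Amide for a Cyclopropyl Sulfonamide

The source may hold more compounds than are shown below. What is called first, only, known or untested is meant among the compounds shown, and "the series" means these compounds.

Compound 3 `O=C(C1CC(F)C1)N1CCc2nc(C#Cc3ccccc3)sc2C1` sits at the edge of what an assay on HEK293 cells for negative allosteric modulation of metabotropic glutamate receptor 5 (Homo sapiens), read by FLIPR, with a stated time of 1 h (on this read-out higher numbers stand for weaker inhibition and lower numbers for stronger inhibition), can report: its value of > 10000 nM is a limit rather than a number (the limit of > 10000 nM in this assay, at which 1 of the 3 values shown sits). Compound 1 `CCC(=O)N1CCc2nc(C#Cc3ccccc3)sc2C1` gives 38 nM in this assay, and compound 2 `O=C(C1CCC1)N1CCc2nc(C#Cc3ccccc3)sc2C1` gives 370 nM. Compound 4 `O=S(=O)(C1CC1)N1CCc2nc(C#Cc3ccccc3)sc2C1` differs from compound 3 in one place: cyclopropylsulfonyl in place of (3-fluorocyclobutyl)carbonyl on an amine nitrogen in a ring. The measured steps bear on this only partly. The step of a 9.7-fold higher number from compound 1 to compound 2 (0.99 log units; beyond the scatter) was modest, the step of an at least 27-fold higher number from compound 2 to compound 3 (1.43 log units; beyond the scatter) was large, and the step of an at least 260-fold higher number from compound 1 to compound 3 (2.42 log units; beyond the scatter) was large. Within the data shown here, no measured step puts a sulfonyl in place of a carbonyl, so the departure of the fluoro and of the four-membered ring suggests some recovery of inhibition, though of uncertain size. Compound 4 is expected to reach 1000 nM, within 100 nM to 10000 nM, which would mean an expected at least 10-fold lower number from compound 3 to compound 4 (1.00 log units; beyond the scatter).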

Compound 4, half-maximal inhibitory concentration: 34 nM
Estimate against measurement, compound 4: 29-fold (1.47 log units) above; the measured number lies below the stated range.
By their numbers in this assay, from the lowest: compounds 4 and 1 (each within the scatter of the next); then compound 2. At a limit, above all of these: compound 3.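

The value of compound 3 is a limit, not a number: the limit of > 10000 nM in this assay, at which 1 of the 4 values shown sits. Cyclopropylsulfonyl on the amine nitrogen in a ring gives an at least 290-fold lower number from compound 3 to compound 4 (2.46 log units; beyond the scatter) against (3-fluorocyclobutyl)carbonyl and an 11-fold lower number from compound 2 to compound 4 (1.04 log units; beyond the scatter) against cyclobutylcarbonyl on the same nitrogen. Against propanoyl, a 1.1-fold lower number from compound 1 to compound 4 (0.05 log units; within the scatter) shows that a sulfonyl can take the place of a carbonyl here and match compound 1.

Going by these compounds, only one sulfonyl appears, so it stays open how much of the change belongs to the sulfonyl and how much to the cyclopropyl ring. A cyclopropylcarbonyl or an ethylsulfonyl group would separate the two.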